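This account rests on a few compounds, and the source may have more. Where it says the series, first, only, none or still open, it means among the compounds named here.

Compound 1, with the structure `Nc1scc(CN2CCN(c3ccc(Cl)c(C(F)(F)F)c3)CC2)c1C(=O)c1ccc(Cl)cc1`, was tested in a functional assay on CHO cells with adenosine receptor A1 (Homo sapiens) as the target, read by cAMP accumulation and immunoassay, with a stated time of 6 min, tested at 10 uM (a lower number here means a stronger effect, a higher number a weaker effect of the compound at the concentration tested), where compound 1 gives -60%. A second member of the same series, compound 2, with the structure `Nc1scc(CN2CCN(c3cccc(F)c3)CC2)c1C(=O)c1cccc(C(F)(F)F)c1`, gives -62% in this assay. These two numbers lie within the usual scatter of each other, so the data show no separation between compound 1 and compound 2, even though the two carry different groups on the amine nitrogen in the ring and on the carbonyl side.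

The next compound, compound 3, has the structure `Nc1scc(CN2CCN(c3cc(F)cc(F)c3)CC2)c1C(=O)c1ccc(Cl)cc1`. It keeps the shared core of compound 1 and differs from it in one place: 3,5-difluorophenyl in place of 4-chloro-3-(trifluoromethyl)phenyl on an amine nitrogen in a ring.

Within the data shown here, with only two measured compounds, and no pair among them that differs in a single place, there is no directly comparable step to draw on. Since compound 1 and compound 2 give near-identical read-outs despite differing groups in the same region, the change to compound 3 is expected to produce a step of a number 5 percentage points higher from compound 1 to compound 3 (within the scatter), that is, none beyond the scatter. Compound 3 is therefore expected to give about -55%, within a range from -75% to -35%.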

Compound 3, a percentage reported as activity, at one concentration (the size of the read-out at that concentration, not a potency): -79%
The estimate for compound 3 lay 24 percentage points above the measured number, and the stated range ends above it.
By their numbers in this assay, from the lowest: compound 3; then compounds 2 and 1 (each within the scatter of the next).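

The group on the amine nitrogen in a ring turns out to matter in this assay: replacing 4-chloro-3-(trifluoromethyl)phenyl with 3,5-difluorophenyl gives a number 19 percentage points lower from compound 1 to compound 3 (beyond the scatter), a modest step and a stronger effect at the concentration tested. Among these compounds, this is the first change in a single place that can be read, so the earlier similarity of compound 1 and compound 2, which differ in more than one place, did not show that this position was without influence. The incoming ring has fewer heavy atoms than the one it replaces, and it carries only fluorine, yet nothing measured here accounts for the step.

This single swap changes the chlorine, the trifluoromethyl and the fluorine pattern together, so it leaves open which of them goes with the stronger effect. Plain phenyl, 3,5-dichlorophenyl or a non-aromatic cyclohexyl on the same nitrogen, with the rest of compound 1 kept, would help to separate these possibilities.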